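The source may hold more compounds than are shown below. What is called first, only, known or untested is meant among the compounds shown, and "the series" means these compounds.

Compound 1 `Cc1ccccc1Nc1ncnn1-c1cccc(Cl)c1Cl`: 17.8 nM
Compound 2 `Clc1cccc(-n2ncnc2NCc2ccccc2)c1Cl`: 47.9 nM
Compound 3 `COc1ccccc1CNc1ncnn1-c1cccc(Cl)c1Cl`: 57.5 nM

In a functional assay for antagonist activity at P2X purinoceptor 7 (Homo sapiens), read by FLIPR and calcium flux (a lower number here means a stronger inhibitor, a higher number a weaker inhibitor), compound 3 gives the highest of the three numbers, yet the nearer gap is only a 1.2-fold higher number from compound 2 to compound 3 (0.08 log units; within the scatter), so those two cannot be ordered; the clear gap is to compound 1, whose number is lower. Compound 4 `CSc1ccccc1CNc1ncnn1-c1cccc(Cl)c1Cl` differs from compound 3 by methylsulfanyl in place of methoxy on an aromatic carbon. Of the measured steps, a 1.2-fold higher number from compound 2 to compound 3 (0.08 log units; within the scatter) touches the same ring and stayed within the scatter, while a 2.7-fold higher number from compound 1 to compound 2 (0.43 log units; beyond the scatter) concerned another part of the molecule. Neither tells how methylsulfanyl compares with methoxy, so no step beyond the scatter is expected, a 1.0-fold lower number from compound 3 to compound 4 (0.02 log units; within the scatter). Compound 4 is therefore estimated at 55 nM, between 20 nM and 150 nM.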

Compound 4, half-maximal inhibitory concentration: 49 nM
Compound 4: middle estimate off by 1.1-fold (0.05 log units), on the high side; the measured number falls inside the stated range.
By their numbers in this assay, from the lowest: compound 1; then compounds 2, 4 and 3 (each within the scatter of the next).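

In this assay, exchanging methoxy for methylsulfanyl gives a 1.2-fold lower number from compound 3 to compound 4 (0.07 log units; within the scatter), and methylsulfanyl in place of hydrogen gives a 1.0-fold higher number from compound 2 to compound 4 (0.01 log units; within the scatter). Hydrogen, methoxy and methylsulfanyl on this aromatic carbon, ortho to a large group, therefore cannot be told apart by these numbers, and the exchange of oxygen for sulfur brings no measurable shift. Nothing available explains this lack of separation.

On these data alone, whether an amine, a carboxylic acid or a longer chain at this carbon would move the number beyond the scatter remains open.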